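Two Bicyclic Amines Stay Non-Toxic; A Third Expected Alike

A few compounds are considered here, and "the series" means these few. Any claim that something is new, unique, unknown or untested is made for them only; others in the source may bear on it.

Compound 1, `C[C@H]1[C@H](N)C[C@@H]2C[C@H]1C2(C)C`: > 300000 nM
Compound 2, `C[C@H]1[C@H](CN)C[C@@H]2C[C@H]1C2(C)C`: > 300000 nM

In an ADME assay on MDCK cells (Canis lupus familiaris) for cytotoxicity, read by CCK-8 assay, with a stated time of 72 h (on this read-out lower numbers stand for higher toxicity in this test and higher numbers for lower toxicity in this test), compound 1 gives > 300000 nM, which is a limit of the assay rather than a number. Compound 2, `C[C@H]1[C@H](CN)C[C@@H]2C[C@H]1C2(C)C`, likewise gives only the limit > 300000 nM in this assay. The step that the two limits leave unreadable from compound 1 to compound 2 therefore cannot be read in size. Both values sit at the same point, (the limit of > 300000 nM in this assay, at which 2 of the 2 values shown sit), so compound 2 stands at that limit in this assay with no measured number of its own.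

Compound 3, `C[C@H]1[C@H]([C@H](C)N)C[C@@H]2C[C@H]1C2(C)C`, differs from compound 2 by methyl in place of hydrogen on a saturated chain carbon bound to an amine nitrogen and a saturated ring carbon. Among the measured compounds shown here, the only measured step is unreadable and offers no direction, so no step beyond the scatter is expected in this assay. Compound 3 is expected to give 300000 nM, between 150000 nM and 600000 nM, most likely again reported only as a limit. The expected step from compound 2 to compound 3 is estimated as a number no higher from compound 2 to compound 3 (the limit leaves the size open).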

Compound 3, minimum cytotoxic concentration: > 300000 nM
Compound 3 gave a limit, no number (the forecaster's own chance of this, stated with the estimate: 85%); the middle value sits exactly at the limit.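

Compound 1, compound 2 and compound 3 all end at the same limit, not at numbers, so no step among them can be read: the limit of > 300000 nM in this assay, at which 3 of the 3 values shown sit.

The compounds shown leave open whether amino, aminomethyl and 1-aminoethyl differ at all in this assay.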